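Five-membered aromatic rings on a shared core: the next swap

This account rests on a few compounds, and the source may have more. Where it says the series, first, only, none or still open, it means among the compounds named here.

In a functional assay on KB cells (Homo sapiens) for cytotoxicity (a higher number here means that more compound is needed for the effect, a lower number that less compound is needed), three compounds with one shared core differ only in the ring on a carbon with a double bond to nitrogen. Compound 1 (`Clc1ccc2c(N/N=C/c3ncc[nH]3)ccnc2c1`) gives 19.5 uM, compound 2 (`Clc1ccc2c(N/N=C/c3cccs3)ccnc2c1`) gives 10.4 uM and compound 3 (`Clc1ccc2c(N/N=C/c3ccc[nH]3)ccnc2c1`) gives 4.8 uM. Compound 3 stands lowest of the three, as the data show a 2.2-fold lower number from compound 2 to compound 3 (0.34 log units; beyond the scatter) and a 4.1-fold lower number from compound 1 to compound 3 (0.61 log units; beyond the scatter). The remaining step, a 1.9-fold lower number from compound 1 to compound 2 (0.27 log units; within the scatter), does not separate the other two.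

Compound 4 (`Cc1noc(C)c1/C=N/Nc1ccnc2cc(Cl)ccc12`) is still unmeasured, and its change is 3,5-dimethyl-1,2-oxazol-4-yl in place of 1H-pyrrol-2-yl on a carbon with a double bond to nitrogen. Within the data shown here, no measured compound carries the entering group, so the guidance is indirect. Both measured steps involving the 1H-pyrrol-2-yl group were modest, and each places the alternative ring at the higher number. A step of similar modest size towards a higher number is therefore expected in this assay, and the estimated step is a 2.1-fold higher number from compound 3 to compound 4 (0.32 log units; beyond the scatter). For compound 4 the estimated value is 10 uM, with an expected range of 4 uM to 25 uM.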

Compound 4, concentration for half-maximal effect: 171 uM
Compound 4: the middle estimate sits 17-fold (1.23 log units) below what was measured; the measured number lies above the stated range.
By their numbers in this assay, from the lowest: compound 3; then compounds 2 and 1 (each within the scatter of the next); then compound 4.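

In this assay the ring on a carbon with a double bond to nitrogen proves able to move the number much further than the first three compounds showed, with large steps against the 1H-pyrrol-2-yl and thiophen-2-yl rings (a 36-fold higher number from compound 3 to compound 4 (1.55 log units; beyond the scatter)) (a 16-fold higher number from compound 2 to compound 4 (1.22 log units; beyond the scatter)). Against the 1H-imidazol-2-yl ring the step is smaller, though still beyond the scatter (an 8.8-fold higher number from compound 1 to compound 4 (0.94 log units; beyond the scatter)), so 3,5-dimethyl-1,2-oxazol-4-yl stands above all three earlier rings with no compound going against that order. Nothing measured here accounts for the size of these steps.

The change replaces the ring and also brings in two methyl groups, and the compounds shown do not separate these two parts. A 1,2-oxazol-4-yl ring without methyl groups, or a 1H-pyrrol-2-yl ring carrying two methyl groups, would bear on that question.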